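From 2-Aminobenzyl to 2,5-Dihydroxybenzyl in a Cytotoxicity Series

This account rests on a few compounds, and the source may have more. Where it says the series, first, only, none or still open, it means among the compounds named here.

Of the compounds shown here, three sharing one core have been measured in a functional assay on P388 cells (Mus musculus) for cytotoxicity; a higher number here means a weaker inhibitor, a lower number a stronger inhibitor. Compound 1 `Cc1cc(-c2c(F)cc3c(=O)c(Cc4c(O)cccc4O)cn(C4CC4)c3c2F)cc(C)n1`, which carries a 2,6-dihydroxybenzyl group, gives 250 nM. Compound 2 `Cc1cc(-c2c(F)cc3c(=O)c(C(=O)O)cn(C4CC4)c3c2F)cc(C)n1`, with carboxy on that aromatic carbon, gives 29000 nM. Compound 3 `Cc1cc(-c2c(F)cc3c(=O)c(Cc4ccccc4N)cn(C4CC4)c3c2F)cc(C)n1`, with 2-aminobenzyl there, gives 2100 nM, the second highest of the three numbers.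

The next compound, compound 4 `Cc1cc(-c2c(F)cc3c(=O)c(Cc4cc(O)ccc4O)cn(C4CC4)c3c2F)cc(C)n1`, departs from compound 3 in one place: 2,5-dihydroxyphenyl in place of 2-aminophenyl on a saturated chain carbon bound to an aromatic carbon. In words, 2,5-dihydroxyphenyl stands in place of 2-aminophenyl on a saturated chain carbon bound to an aromatic carbon.

For the measured compounds named here, the closest precedent is the modest step of an 8.4-fold higher number from compound 1 to compound 3 (0.92 log units; beyond the scatter), which lies beyond the scatter and links 2-aminophenyl with 2,6-dihydroxyphenyl. The large steps of a 120-fold higher number from compound 1 to compound 2 (2.06 log units; beyond the scatter) and a 14-fold lower number from compound 2 to compound 3 (1.14 log units; beyond the scatter) both involve carboxy and so bear on this change only loosely. Going by the values given here, no compound with the 2,5-dihydroxyphenyl group has been measured yet, so carrying the precedent of compound 1 over to it remains uncertain. A modest move towards a lower number is therefore expected in this assay, and the estimated step is a 6.0-fold lower number from compound 3 to compound 4 (0.78 log units; beyond the scatter). For compound 4 the estimated value is 350 nM, with an expected range from 100 nM to 1300 nM.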

Compound 4, half-maximal inhibitory concentration: 360 nM
Compound 4: middle estimate off by 1.0-fold (0.01 log units), on the low side, within the range that was stated.
By their numbers in this assay, from the lowest: compounds 1 and 4 (each within the scatter of the next); then compound 3; then compound 2.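

Exchanging 2,6-dihydroxyphenyl for 2,5-dihydroxyphenyl on the saturated chain carbon gives a change within the scatter (a 1.4-fold higher number from compound 1 to compound 4 (0.16 log units; within the scatter)), so in this assay these two groups cannot be told apart at this place. For the compounds shown here, the earlier compounds showed a lower number for a dihydroxyphenyl group than for 2-aminophenyl with only one such group; the same direction now appears with a second one (a 5.8-fold lower number from compound 3 to compound 4 (0.77 log units; beyond the scatter)), so the difference from 2-aminophenyl is not tied to the 2,6-dihydroxyphenyl group alone. Placing 2,5-dihydroxybenzyl on the aromatic carbon that bears carboxy in the comparison compound gives a large step (an 81-fold lower number from compound 2 to compound 4 (1.91 log units; beyond the scatter)), which puts this group, like 2,6-dihydroxybenzyl, far from carboxy in this series.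

No measured evidence is available to explain any of these differences. As far as these compounds go, it remains open what a single hydroxy group, a methoxy group or a 3-aminophenyl group would give at this carbon, and whether the two dihydroxyphenyl groups would stay as close on a longer chain.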